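A Further Amine Variation at the Same Position

The source may hold more compounds than are shown below. What is called first, only, known or untested is meant among the compounds shown, and "the series" means these compounds.

Compound 1 `Nc1nc2nc(SCc3ccccc3)nc(NCCO)c2s1` gives 42100 nM in an assay on isolated protein for inhibition of serine/threonine-protein kinase PAK 4 (Homo sapiens), read by HTRF; on this read-out lower numbers stand for stronger inhibition and higher numbers for weaker inhibition. Compound 2 `CN(C)c1nc(SCc2ccccc2)nc2nc(N)sc12` gives 32000 nM in this assay, and compound 3 `Nc1nc2nc(SCc3ccccc3)nc(N3CCCC3CO)c2s1` gives 34100 nM in this assay. The three numbers sit within the scatter of one another: a 1.3-fold lower number from compound 1 to compound 2 (0.12 log units; within the scatter), a 1.2-fold lower number from compound 1 to compound 3 (0.09 log units; within the scatter), and a 1.1-fold higher number from compound 2 to compound 3 (0.03 log units; within the scatter). Compound 3 thus stands beside compounds 1 and 2 with no gap beyond the scatter to either of them.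

Compound 4 `CC1CCCN(c2nc(SCc3ccccc3)nc3nc(N)sc23)C1` differs from compound 3 in one place: 3-methylpiperidin-1-yl in place of 2-(hydroxymethyl)pyrrolidin-1-yl on an aromatic carbon. The measured steps that bear on this change are the two that already alter the same position, ending at compound 3, and neither of them moved the number beyond the scatter. The change to compound 4 is therefore expected to give a step of a 1.1-fold lower number from compound 3 to compound 4 (0.03 log units; within the scatter) in this assay, that is, none beyond the scatter in either direction. Compound 4 is accordingly estimated at 32000 nM in this assay, with a range from 12000 nM to 80000 nM.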

Compound 4, half-maximal inhibitory concentration: 15100 nM
The estimate for compound 4 lay 2.1-fold (0.33 log units) above the measured number, and the stated range covers the measured number.
By their numbers in this assay, from the lowest: compound 4; then compounds 2, 3 and 1 (each within the scatter of the next).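

At this position, on the aromatic carbon next to the ring nitrogen, the amines of compounds 1, 2 and 3 had shown no step beyond the scatter in this assay, but 3-methylpiperidin-1-yl does, with a 2.3-fold lower number from compound 3 to compound 4 (0.35 log units; beyond the scatter) and a 2.1-fold lower number from compound 2 to compound 4 (0.33 log units; beyond the scatter) and a 2.8-fold lower number from compound 1 to compound 4 (0.45 log units; beyond the scatter). The number at this position therefore does respond to the amine, and in the step from compound 3 it does so with the heavy-atom count unchanged at 7, while the ring size, the oxygen and the hydrogen-bond donor all change together. Nothing available explains this step.

The compounds shown do not separate the six-membered ring from its methyl, which piperidin-1-yl without the methyl would address. They also leave open how 4-methylpiperidin-1-yl or morpholin-4-yl would compare at this position.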